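The source may report more compounds than this note shows. Statements on the series, on what has been measured and on what is new or still open speak of the compounds shown alone.

Values in an ADME assay, in phosphate buffer, with a stated time of 30 min, tested at 1 mM, at a dose of 1 mM, in the presence of a further agent that is not named here; on this read-out lower numbers stand for lower exposure and higher numbers for higher exposure at the dose given:
compound 1 `O=c1sn(-c2ccccc2)c(=O)n1Cc1ccccc1` gives 2430 nM
compound 2 `O=c1sn(-c2ccc(F)cc2)c(=O)n1-c1ccccc1` gives 13400 nM
compound 3 `COc1ccc(-n2sc(=O)n(-c3ccc(OC)cc3)c2=O)cc1` gives 31100 nM

Compound 3 stands highest of the three numbers in this assay. Its nearest neighbour is compound 2, whose number is lower by a margin beyond the scatter; the gap to compound 1, which carries a benzyl group on the shared core rather than a second phenyl, is wider still. No two of these compounds differ in a single place, so no single change is isolated by the measured set, and nothing here separates the effect of the methoxy groups from the rest of the structure.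

Compound 4 `COc1ccc(-n2sc(=O)n(-c3ccc(Cl)cc3)c2=O)cc1` is the next compound and has not yet been measured in this assay. It differs from compound 3 in one place:
chloro in place of methoxy on an aromatic carbon
Among the compounds with values here, no measured pair reports this exchange, so the size of the step in this assay is open. What the numbers show is that compound 2, with a halogen on one ring, gives 13400 nM while compound 3 gives 31100 nM. On that basis the step from compound 3 to compound 4 is expected to be small, at most a modest lowering, as a 1.6-fold lower number from compound 3 to compound 4 (0.19 log units; within the scatter). For compound 4 the estimate is 20000 nM, with a range from 8000 nM to 50000 nM.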

Compound 4, maximal plasma concentration: 35700 nM
Compound 4: middle estimate off by 1.8-fold (0.25 log units), on the low side; low and high end bracket the measured number.
By their numbers in this assay, from the lowest: compound 1; then compound 2; then compounds 3 and 4 (each within the scatter of the next).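

In this assay, chloro in place of methoxy on an aromatic carbon, para to a large group, gives a 1.1-fold higher number from compound 3 to compound 4 (0.06 log units; within the scatter). Within the data shown here, this is the first exchange that can be read in one place, and it shows that at this position the read-out does not tell the two groups apart. A methoxy group at this carbon is therefore not needed for a number of this size, at least while the other ring keeps its methoxy, as it does in compound 3 and compound 4. No accompanying measurement bears on this result, so it stands as an observation without an explanation.

On these data alone, it remains open whether the same exchange would read alike on the other ring, or with both methoxy groups replaced, since this single pair speaks only for one position with the rest of the structure held fixed. As far as these compounds go, it is also open whether the read-out would stay level with quite different groups at this carbon, such as an amine, a carboxylic acid or a longer alkoxy chain.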